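The source may hold more compounds than are shown below. What is called first, only, known or untested is meant among the compounds shown, and "the series" means these compounds.

Compound 1 `Cc1c(-c2ccc(-c3ccccc3F)cc2)nc2ccc(F)cc2c1-c1noc(=O)[nH]1`: > 3000 nM
Compound 2 `CCONC(=O)c1c(C)c(-c2ccc(-c3ccccc3F)cc2)nc2ccc(F)cc12`: 33 nM

In a functional assay on MOLM-13 cells (Homo sapiens) for antiproliferative activity (on this read-out lower numbers stand for stronger inhibition and higher numbers for weaker inhibition), the value for compound 1 is a limit of the assay rather than a number, so compound 1 stands at the limit of > 3000 nM in this assay, at which 1 of the 2 values shown sits, and its true position is known only as a ceiling. Going by the values given here, compound 2 is the one measured compound with a definite number. Among the compounds with values here, the single measured step, an at least 90-fold lower number from compound 1 to compound 2 (1.95 log units; beyond the scatter), trades the five-membered ring for an open chain carrying a carbonyl, and it goes with a large fall in the number, measured from the limit.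

Compound 3 `Cc1c(-c2ccc(-c3ccccc3F)cc2)nc2ccc(F)cc2c1C(=O)N(C)O` carries a related change at the same aromatic carbon: a group of 5 heavy atoms (2 carbon, 1 nitrogen, 2 oxygen; no ring) in place of a group of 6 heavy atoms (2 carbon, 2 nitrogen, 2 oxygen; one five-membered aromatic ring with 3 hetero atoms), on an aromatic carbon. The entering hydroxy(methyl)carbamoyl group is again an open chain with a carbonyl and one hydrogen-bond donor, close in kind to the group in compound 2. The step to compound 3 is therefore expected to run in the same direction and to be large, an at least 20-fold lower number from compound 1 to compound 3 (1.30 log units; beyond the scatter), resting on the fall seen in an at least 90-fold lower number from compound 1 to compound 2 (1.95 log units; beyond the scatter). Compound 3 is estimated at 150 nM, within a range from 30 nM to 800 nM.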

Compound 3, half-maximal inhibitory concentration: 5100 nM
Compound 3: the middle estimate sits 34-fold (1.53 log units) below what was measured; the measured number lies above the stated range.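

At this aromatic carbon, an open chain with a carbonyl is not enough on its own: changing only the group on the carbonyl carbon, with hydroxy(methyl)amino in place of ethoxyamino, gives a 150-fold higher number from compound 2 to compound 3 (2.19 log units; beyond the scatter) in this assay. Among these three compounds, only the ethoxyamino group of compound 2 goes with a low number, and compound 3 goes against any rule that replacing the five-membered ring with an open chain lowers the number. The step between compound 1 and compound 3 cannot be read because compound 1 stands only at a limit: the limit of > 3000 nM in this assay, at which 1 of the 3 values shown sits.

Still open, going by these compounds, is which feature of the ethoxyamino group matters, as compound 2 and compound 3 differ both in the amide hydrogen and in the chain on the oxygen. A methoxyamino group, a longer propoxyamino chain or a plain methylamino group on the same carbonyl would help show whether the oxygen, the length of the chain or the amide hydrogen goes with the low number.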